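N-Methylation of the indole-type ring in a CDK8 series

The source may report more compounds than this note shows. Statements on the series, on what has been measured and on what is new or still open speak of the compounds shown alone.

Measured so far:
compound 1 `O=C(/C=C/c1ccncc1-c1ccc2[nH]ccc2c1)N1CCOCC1` 97%
compound 2 `CCOC(=O)/C=C/c1ccncc1-c1ccc2[nH]ccc2c1` 100%
compound 3 `O=C(/C=C/c1ccncc1-c1ccc2cccnc2c1)N1CCOCC1` 33%

In an assay on a protein complex for inhibition of CDK8/Cyclin C (Homo sapiens), with a stated time of 1 h, tested at 10 uM (on this read-out lower numbers stand for less inhibition and higher numbers for more inhibition at the one concentration tested (going by the name of the read-out)), compound 2 stands highest of the three, with compound 1 nearest and compound 3 furthest. Among the measured compounds shown here, the one step that exists, a number 3 percentage points higher from compound 1 to compound 2 (within the scatter), shows that the ester and the morpholine amide behave alike on the carbonyl side. Compound 1 and compound 3 share that amide but differ in the fused ring, and their values sit far apart.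

Compound 4 `CCOC(=O)/C=C/c1ccncc1-c1ccc2c(ccn2C)c1` keeps the ester of compound 2 and carries methyl in place of hydrogen on an aromatic nitrogen. For the measured compounds named here, no measured step touches that aromatic nitrogen, so the size of the step is open; the gap between compound 1 and compound 3 suggests the fused ring matters. A loss beyond the scatter is expected, a number 40 percentage points lower from compound 2 to compound 4 (beyond the scatter), and compound 4 is estimated at 60% within 20% to 95%.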

Compound 4, a percentage reported as inhibition, at one concentration (the size of the read-out at that concentration, not a potency): 100%
Estimate against measurement, compound 4: 40 percentage points below; the whole stated range lies below it.
By their numbers in this assay, from the lowest: compound 3; then compounds 1, 2 and 4 (each within the scatter of the next).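

In this assay, methyl in place of hydrogen on an aromatic nitrogen of the five-membered ring gives no change at the digits printed from compound 2 to compound 4 (within the scatter), so in this ester pair the hydrogen on that nitrogen is not required for inhibition at the one concentration tested. Both compounds sit at the top of the scale, where a change in effect at that concentration could stay hidden. No evidence is available to explain this level result.

Still open, on these data alone, is whether the inhibition in this assay stays level with a longer chain, such as ethyl or a chain ending in an amine, on that nitrogen. Also open, as far as these compounds go, is whether methyl behaves the same way with the morpholine amide of compound 1.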